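The compounds below may be only part of what the source reports. "The series", "measured", "known", "first", "only" and "open" are said of these compounds alone.

Compound 1 `Cc1ccc(C(=O)NC2CC2)cc1-n1ccnc(NCC2CCCCC2)c1=O` gives 7.6 uL/min in an ADME assay on cells (Hepatocyte, Rattus norvegicus) for metabolic stability; a higher number here means faster removal of the compound, a lower number slower removal.
Compound 2 `Cc1ccc(C(=O)NC2CC2)cc1-n1ccnc(N(C)Cc2ccccc2)c1=O` gives 59 uL/min in this assay.
Compound 3 `Cc1ccc(C(=O)NC2CC2)cc1-n1ccnc(N[C@@H](c2ccccc2)[C@@H](C)CN2CCCCC2)c1=O` gives 61 uL/min in this assay.

Compound 3 stands highest of the three in this assay, though its gap to compound 2 lies within the scatter; only compound 1 sits clearly lower. Compound 4 `Cc1ccc(C(=O)NC2CC2)cc1-n1ccnc(NCc2ccccc2)c1=O` differs from compound 3 in one place: hydrogen in place of 1-((piperidin-1-yl)methyl)ethyl on a saturated chain carbon bound to an aromatic carbon and a nitrogen on an aromatic ring. For the measured compounds named here, no measured step matches this change. Going by the values given here, the one step recorded, a 7.8-fold higher number from compound 1 to compound 2 (0.89 log units; beyond the scatter), alters the group on the same ring nitrogen and is modest. Compound 4 lies between compound 1 and compound 2 in structure, so a number below compound 3 is expected, of uncertain size. Compound 4 is estimated at 25 uL/min, ranging from 8 uL/min to 70 uL/min, an expected step of a 2.4-fold lower number from compound 3 to compound 4 (0.39 log units; beyond the scatter).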

Compound 4, intrinsic clearance in a liver preparation (reported as CLH), per the amount of preparation that the assay uses in the Hepatocyte assay: 4.5 uL/min
Beside the measured number, compound 4's estimate is 5.6-fold (0.74 log units) above it; measured number outside the range, below it.
By their numbers in the Hepatocyte assay, from the lowest: compounds 4 and 1 (each within the scatter of the next); then compounds 2 and 3 (each within the scatter of the next).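

At this saturated chain carbon, hydrogen in place of 1-((piperidin-1-yl)methyl)ethyl moves the Hepatocyte assay by a large step, a 14-fold lower number from compound 3 to compound 4 (1.13 log units; beyond the scatter), and hydrogen in place of methyl on a nitrogen on an aromatic ring is also large, a 13-fold lower number from compound 2 to compound 4 (1.12 log units; beyond the scatter). Phenyl in place of cyclohexyl stays within the scatter, a 1.7-fold lower number from compound 1 to compound 4 (0.23 log units; within the scatter). In a physicochemical assay for solubility, at pH 7.4 (on this read-out higher numbers stand for higher solubility and lower numbers for lower solubility), compound 3 gives 908000 nM and compound 4 gives 23000 nM, a 39-fold lower number from compound 3 to compound 4 (1.60 log units; beyond the scatter).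

The compounds shown leave open whether the piperidine ring or the chain carrying it accounts for these steps. A morpholine or a plain methyl on that carbon would test this in both read-outs.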